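Adding fluoro beside bromo on a weak cytotoxic scaffold

This account rests on a few compounds, and the source may have more. Where it says the series, first, only, none or still open, it means among the compounds named here.

Compound 1 `C=CCn1c(=O)/c(=C\c2ccccc2Cl)[nH]c(=O)/c1=C\c1ccccc1OC`: 9200 nM
Compound 2 `C=CCn1c(=O)/c(=C\c2ccc(Cl)c(Cl)c2)[nH]c(=O)/c1=C\c1ccccc1OC`: "not active" (no number reported)
Compound 3 `C=CCn1c(=O)/c(=C\c2cccc(Br)c2)[nH]c(=O)/c1=C\c1ccccc1OC`: "not active" (no number reported)

All three compounds share one core and were tested in a functional assay on NCI-H1975 cells (Homo sapiens) for cytotoxicity, read by CCK-8 assay, with a stated time of 72 h; a lower number here means a stronger inhibitor, a higher number a weaker inhibitor. Compound 1 gives 9200 nM, a weak result. Compound 2 is reported as "not active" (no number reported), with no number attached. Compound 3 is likewise reported as "not active" (no number reported). Compound 3 therefore stands with no number of its own, alongside one other compound in the same position; only compound 1 carries a measured value here.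

Compound 4 `C=CCn1c(=O)/c(=C\c2ccc(F)c(Br)c2)[nH]c(=O)/c1=C\c1ccccc1OC` is the compound still to be measured. It differs from compound 3 in a single place: fluoro in place of hydrogen on an aromatic carbon. No step between measured compounds exists in this set, so nothing shown tells how large such a change can be.

Given that compound 3 is reported without a number in this assay, compound 4 is expected to remain weak, with a change of at most the usual scatter in either direction. The estimate for compound 4 is 20000 nM, within a range from 6000 nM to 60000 nM, and a report of no number at all is thought likely.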

Compound 4, half-maximal inhibitory concentration: "not active" (no number reported)
No number was reported for compound 4, and the estimate cannot be compared.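

In this assay, for the compounds shown here, compound 3 and compound 4 are both reported as not active, with no number, and no step between them can be read. The compounds shown leave open whether adding fluoro to the 3-bromophenyl group changes cytotoxicity at all. No supporting measurement bears on this result.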